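This account rests on a few compounds, and the source may have more. Where it says the series, first, only, none or still open, it means among the compounds named here.

Compound 1 `Clc1ccccc1CSc1nnc(-c2ccc3c(c2)OCCO3)n1-c1ccccc1`: 17400 nM
Compound 2 `Clc1cccc(CSc2nnc(-c3ccc4c(c3)OCCO4)n2-c2ccccc2)c1`: 51200 nM
Compound 3 `Cc1ccccc1CSc1nnc(-c2ccc3c(c2)OCCO3)n1-c1ccccc1`: > 100000 nM

All three were tested in a functional assay on BGC-823 cells (Homo sapiens) for antiproliferative activity, read by MTT assay, with a stated time of 24 h; on this read-out higher numbers stand for weaker inhibition and lower numbers for stronger inhibition. Compound 3 has only a limit, > 100000 nM, and not a number. Compound 4 `Brc1ccccc1CSc1nnc(-c2ccc3c(c2)OCCO3)n1-c1ccccc1` carries bromo in place of methyl on an aromatic carbon, ortho to a large group: bromo in place of methyl on an aromatic carbon. The most relevant measured step is an at least 5.7-fold higher number from compound 1 to compound 3 (0.75 log units; beyond the scatter), where methyl replaces chloro at that same place. The step of an at least 1.9-fold higher number from compound 2 to compound 3 (0.29 log units; that floor lies within the scatter) adds little, as its floor lies within the scatter. Because of an at least 5.7-fold higher number from compound 1 to compound 3 (0.75 log units; beyond the scatter) a step of at least modest size towards lower numbers is expected in this assay on going to bromo. The expected step is an at least 5.0-fold lower number from compound 3 to compound 4 (0.69 log units; beyond the scatter). For compound 4 the estimated value is 20000 nM, within a range of 7000 nM to 60000 nM.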

Compound 4, half-maximal inhibitory concentration: > 100000 nM
Compound 4 ended at the assay's limit; the forecaster's own chance of this, stated with the estimate: 10%; middle value at least 5.0-fold (0.69 log units) from the limit.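

Swapping chloro for bromo on this aromatic carbon, ortho to a large group, does not preserve the result: the change gives an at least 5.7-fold higher number from compound 1 to compound 4 (0.75 log units; beyond the scatter), so among the groups shown here, a second halogen fares no better than methyl. The other new step, an at least 1.9-fold higher number from compound 2 to compound 4 (0.29 log units; that floor lies within the scatter), has a floor within the scatter and so sets no order. The step between methyl and bromo cannot be read, with both compounds sitting at the limit: the limit of > 100000 nM in this assay, at which 2 of the 4 values shown sit.

As far as these compounds go, whether fluoro, methoxy or an amine at this place would give a measurable number remains open.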